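Replacing dimethylcarbamoyl with 5-methyl-1,3,4-oxadiazol-2-yl: working notes

A few compounds are considered here, and "the series" means these few. Any claim that something is new, unique, unknown or untested is made for them only; others in the source may bear on it.

Measured so far in an ADME assay on Vero cells (Chlorocebus sabaeus) for cytotoxicity, read by MTT assay; on this read-out lower numbers stand for stronger inhibition and higher numbers for weaker inhibition:
- compound 1 `COC(=O)c1nc(C)c2c(c1N)C(=O)N(Cc1ccccc1)C2=O`: "not determined" (no result reported)
- compound 2 `CNC(=O)c1nc(C)c2c(c1N)C(=O)N(Cc1ccccc1)C2=O`: "not determined" (no result reported)
- compound 3 `Cc1nc(C(=O)N(C)C)c(N)c2c1C(=O)N(Cc1ccccc1)C2=O`: > 100000 nM (a limit)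

Compound 3 stands at > 100000 nM in this assay, which is a limit and not a number. Going by the values given here, the only evidence is a single entry: the limit of > 100000 nM in this assay, at which 1 of the 3 values shown sits. Compound 4 `Cc1nnc(-c2nc(C)c3c(c2N)C(=O)N(Cc2ccccc2)C3=O)o1` carries 5-methyl-1,3,4-oxadiazol-2-yl in place of dimethylcarbamoyl on an aromatic carbon. Among the compounds with values here, no measured step exists to size this change, so no step beyond the scatter is expected, with any move more likely toward stronger inhibition. The expected change is a number no higher from compound 3 to compound 4 (the limit leaves the size open). For compound 4 the estimated value is 100000 nM, with an expected range of 30000 nM to 200000 nM.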

Compound 4, half-maximal inhibitory concentration in the Vero assay: > 100000 nM
Compound 4: only a limit was reported (the forecaster's own chance of this, stated with the estimate: 70%); the middle value lies on the limit itself.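

In the Vero assay compound 3 gives > 100000 nM as a limit. In the Vero assay compound 4 gives > 100000 nM as a limit. No step can be read between them. The compounds shown leave open whether 5-methyl-1,3,4-oxadiazol-2-yl in place of dimethylcarbamoyl shifts this read-out at all. In a physicochemical assay for solubility, using the shake flask method, in simulated intestinal fluid, measured as kinetic solubility, with a stated time of 2 h, at 25 degrees C, at pH 6.5 (a lower number here means a less soluble compound, a higher number a more soluble compound), compound 3 gives 172000 nM as a measured value. In the physicochemical assay compound 4 gives < 5000 nM as a limit.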